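This account rests on a few compounds, and the source may have more. Where it says the series, first, only, none or still open, it means among the compounds named here.

Compound 1 `N#C/C(=C\c1ccc([N+](=O)[O-])cc1)C(=O)c1c[nH]c2ccccc12` and compound 2 `N#C/C(=C\c1c(F)c(F)c(F)c(F)c1F)C(=O)c1c[nH]c2ccccc12` share one core and differ in a single ring. In a functional assay on DU-145 cells (Homo sapiens) for inhibition, read by MTT assay, with a stated time of 72 h (a lower number here means a stronger inhibitor of growth, a higher number a weaker inhibitor of growth), compound 1 gives 59000 nM. In this assay compound 2 gives 30000 nM. Compound 3 `COc1ccc(CNC(=O)/C(C#N)=C/c2ccc[nH]2)cc1` carries a different amide part together with a 1H-pyrrol-2-yl group. For compound 3 this assay records only a limit, > 50000 nM, and not a number. That is the line described as the limit of > 50000 nM in this assay, at which 1 of the 3 values shown sits, so compound 3 stands at the edge of what the assay reports, not at a measured point. Compound 4 `COc1ccc(CNC(=O)/C(C#N)=C/c2ccc(C)o2)cc1` has not yet been measured in this assay. Against compound 3 the change is 5-methylfuran-2-yl in place of 1H-pyrrol-2-yl on a double-bonded chain carbon bound to a double-bonded chain carbon. For the measured compounds named here, no step between measured compounds is at hand for this exchange, and compound 3 itself gives only a limit, so the direction cannot be read from the series; the expectation is a step of no size beyond the scatter, with a limit again the most likely report. Compound 4 is expected at 60000 nM in this assay, between 20000 nM and 200000 nM. The step this estimate implies is a step that the limit leaves unreadable from compound 3 to compound 4, resting on the limit of compound 3 alone.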

Compound 4, concentration for 50% growth inhibition: 39000 nM
For compound 4 the middle estimate is 1.5-fold (0.19 log units) above the measured one, within the range that was stated.
By their numbers in this assay, from the lowest: compounds 2, 4 and 1 (each within the scatter of the next).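

With 5-methylfuran-2-yl in place of 1H-pyrrol-2-yl on a double-bonded chain carbon bound to a double-bonded chain carbon, this assay gives a number for this amide, which compound 3 did not give. The exchange yields an at least 1.2-fold lower number from compound 3 to compound 4 (0.10 log units; that floor lies within the scatter), a floor only, so neither a real gain nor its true size can be stated. Compound 3 remains a limit, and the step rests on that limit: the limit of > 50000 nM in this assay, at which 1 of the 4 values shown sits.

The compounds shown do not separate the ring oxygen from the methyl group of 5-methylfuran-2-yl, and a plain furan-2-yl or a 1-methylpyrrol-2-yl group in this place would address that. Also open, going by these compounds, is whether a ring carrying an amine or a carboxylic acid in this place would move the number beyond the scatter.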